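The source may report more compounds than this note shows. Statements on the series, on what has been measured and on what is new or still open speak of the compounds shown alone.

Of the compounds shown here, two sharing one core have been tested in a functional assay on K562 cells (Homo sapiens) for inhibition, read by fluorescence, with a stated time of 72 h; a higher number here means a weaker inhibitor of growth, a lower number a stronger inhibitor of growth. Compound 1 `CC(C)CCn1cnc2c(NCc3cccc(Cl)c3)nc(N[C@H]3CC[C@H](N)CC3)nc21` gives 3100 nM. Among the compounds with values here, compound 2 `CC(C)CCn1cnc2c(Nc3ccccc3)nc(N[C@H]3CC[C@H](N)CC3)nc21` gives 3500 nM; its only measured neighbour is compound 1, and the step of a 1.1-fold higher number from compound 1 to compound 2 (0.05 log units; within the scatter) lies within the scatter, so the two stand level. Compound 3 `CCCCn1cnc2c(Nc3ccccc3)nc(N[C@H]3CC[C@H](N)CC3)nc21` differs from compound 2 by hydrogen in place of methyl on a saturated chain carbon bound to two saturated chain carbons. Within the data shown here, no measured step touches this saturated chain, since the one known step concerns a group on a nitrogen on an aromatic ring, so nothing points to a shift beyond the scatter. Compound 3 is therefore expected to give 3500 nM, between 1500 nM and 8000 nM. The step of no change at the digits printed from compound 2 to compound 3 (within the scatter) is expected to stay within the scatter.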

Compound 3, concentration for 50% growth inhibition: 3200 nM
Beside the measured number, compound 3's estimate is 1.1-fold (0.04 log units) above it, within the range that was stated.
By their numbers in this assay, from the lowest: compounds 1, 3 and 2 (each within the scatter of the next).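

In this assay the change from isopentyl to butyl gives a 1.1-fold lower number from compound 2 to compound 3 (0.04 log units; within the scatter) and so leaves the two level. Within the data shown here, this is the first look at the saturated chain, and here losing this methyl does not move the number beyond the scatter. Nothing measured here offers an explanation for this. On these data alone, whether a longer chain, or an amine or a carboxylic acid in place of this chain, would shift the number remains open. So does whether butyl would behave the same way alongside 3-chlorobenzyl instead of phenyl.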